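A few compounds are considered here, and "the series" means these few. Any claim that something is new, unique, unknown or untested is made for them only; others in the source may bear on it.

Three compounds sharing one core were tested in an ADME assay on HEK293 cells (Homo sapiens) for cytotoxicity, read by MTT assay, with a stated time of 36 h; on this read-out lower numbers stand for stronger inhibition and higher numbers for weaker inhibition. In this assay compound 1 `O=C(c1ccc2c(c1)OCCO2)C1CCN(Cc2coc(-c3ccc(Cl)cc3)n2)CC1` gives > 150 ug/mL, which is a limit of the assay and not a number. Compound 2 `O=C(c1ccc2c(c1)OCCO2)C1CCN(Cc2coc(-c3ccc(C(F)(F)F)cc3)n2)CC1` likewise gives > 150 ug/mL, again a limit. Compound 3 `O=C(c1ccc2c(c1)OCCO2)C1CCN(Cc2coc(-c3cccc(F)c3)n2)CC1` gives > 150 ug/mL, also a limit. The steps between them cannot be sized: a step that the two limits leave unreadable from compound 1 to compound 2, a step that the two limits leave unreadable from compound 1 to compound 3 and a step that the two limits leave unreadable from compound 2 to compound 3 are all left unreadable because every value sits at the limit of > 150 ug/mL in this assay, at which 3 of the 3 values shown sit. Compound 3 therefore stands only at a limit, as do the two other compounds, and no ordering among the three can be read.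

Compound 4 `COc1ccc(-c2nc(CN3CCC(C(=O)c4ccc5c(c4)OCCO5)CC3)co2)cc1` differs from compound 3 by 4-methoxyphenyl in place of 3-fluorophenyl on an aromatic carbon. Going by the values given here, the steps that bear on this change are those in which the aryl group on the shared core was exchanged, from compound 1 to compound 3 and from compound 2 to compound 3, and both were unreadable. In this assay the expected step that the limit leaves unreadable from compound 3 to compound 4 is thus none beyond the scatter. Compound 4 is expected to give 200 ug/mL, within the range 100 ug/mL to 400 ug/mL, most likely reported again only as a limit.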

Compound 4, half-maximal inhibitory concentration: > 150 ug/mL
Compound 4 ended at the assay's limit (the forecaster's own chance of this, stated with the estimate: 85%); the middle value lies beyond the limit too.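

No new step can be read from compound 4 to compound 1, compound 2 or compound 3 in this assay, because all four compounds stand at one limit and not at a number: the limit of > 150 ug/mL in this assay, at which 4 of the 4 values shown sit.

The compounds shown leave open how the four rank and at what value, if any, each would reach half-maximal inhibition.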